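The source may report more compounds than this note shows. Statements on the series, on what has been measured and on what is new or still open speak of the compounds shown alone.

Two compounds have measured values. In a functional assay on MDA-MB-231 cells (Homo sapiens) for inhibition, read by sulforhodamine B assay, tested at 10 uM (a lower number here means less inhibition, a higher number more inhibition at the concentration tested (going by the name of the read-out)), compound 1 `CN(C)c1ccc(C2CC(c3ccc(-n4ccnc4)cc3)=NN2)cc1` gives 7.6%. In this assay compound 2 `CN1CCN(c2ccc(C3=NN(C(=O)c4ccc(C(F)(F)F)cc4)C(c4ccc(N(C)C)cc4)C3)cc2)CC1` gives 55.4%.

Compound 2 stands highest of the two numbers, with compound 1 the nearest and a number beyond the scatter below it. Compound 3 `CN1CCN(c2ccc(C3=NN(S(=O)(=O)c4ccc(C#N)cc4)C(c4ccc(N(C)C)cc4)C3)cc2)CC1` differs from compound 2 by (4-cyanophenyl)sulfonyl in place of (4-(trifluoromethyl)phenyl)carbonyl on an amine nitrogen in a ring. Within the data shown here, no step between measured compounds covers such a change, so nothing in the data sets its size; a step no larger than the scatter, or a modest one downward, is expected, namely a number 10.4 percentage points lower from compound 2 to compound 3 (beyond the scatter). Compound 3 is therefore estimated to give 45%, expected within 20% to 70%.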

Compound 3, a percentage reported as inhibition, at one concentration (the size of the read-out at that concentration, not a potency): 99.8%
Compound 3: the middle estimate sits 54.8 percentage points below what was measured; measured number above the stated range.
By their numbers in this assay, from the lowest: compound 1; then compound 2; then compound 3.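

At this position, the amine nitrogen in the five-membered ring, the group attached has a large influence in this assay: (4-cyanophenyl)sulfonyl in place of (4-(trifluoromethyl)phenyl)carbonyl gives a number 44.4 percentage points higher from compound 2 to compound 3 (beyond the scatter). The change alters both the sulfonyl-for-carbonyl link and the nitrile-for-trifluoromethyl ring substituent, so the step cannot be assigned to either alone. No measurement at hand explains the step. The compounds shown leave open whether (4-(trifluoromethyl)phenyl)sulfonyl or (4-cyanophenyl)carbonyl on this nitrogen would give a similar number. They also leave open whether methanesulfonyl, which has no aromatic ring, would.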